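Methylphenyl variants: compound 2 to compound 3

The source may hold more compounds than are shown below. What is called first, only, known or untested is meant among the compounds shown, and "the series" means these compounds.

For the measured compounds named here, the two measured members are compound 1 `Cc1ccc(NC(=S)NN=C(c2ccccc2)c2ccccc2)cc1` and compound 2 `Cc1cccc(NC(=S)NN=C(c2ccccc2)c2ccccc2)c1`. In a functional assay on Jurkat cells (Homo sapiens) for antiproliferative activity, read by MTT assay, with a stated time of 48 h (on this read-out higher numbers stand for weaker inhibition and lower numbers for stronger inhibition), compound 1 gives 19 nM and compound 2 gives 9.5 nM. The only measured step is a 2.0-fold lower number from compound 1 to compound 2 (0.30 log units; within the scatter), so on the numbers shown compound 2 and compound 1 lie within the scatter of each other, and compound 2 is the point of departure here. Compound 3 `Cc1ccccc1NC(=S)NN=C(c1ccccc1)c1ccccc1` has not yet been measured; it differs from compound 2 by 2-methylphenyl in place of 3-methylphenyl on an amide-type nitrogen. Going by the values given here, the one measured step that bears on this change is the earlier move of the methyl group from one position on the phenyl ring to another, which stayed within the scatter. Among the compounds with values here, no measured step gives grounds for a change beyond the scatter in this assay in either direction. The expected step is accordingly a 1.3-fold higher number from compound 2 to compound 3 (0.10 log units; within the scatter). The estimate for compound 3 in this assay is 12 nM, with a range from 5 nM to 30 nM.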

Compound 3, half-maximal inhibitory concentration: 15 nM
The estimate for compound 3 lay 1.3-fold (0.10 log units) below the measured number, within the range that was stated.
By their numbers in this assay, from the lowest: compounds 2, 3 and 1 (each within the scatter of the next).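

With the 2-methylphenyl group on the amide-type nitrogen, the series in this assay now holds the 2-methylphenyl, 3-methylphenyl and 4-methylphenyl variants, and both new comparisons, a 1.6-fold higher number from compound 2 to compound 3 (0.20 log units; within the scatter) and a 1.3-fold lower number from compound 1 to compound 3 (0.10 log units; within the scatter), lie within the scatter. The earlier result for the 3-methylphenyl and 4-methylphenyl pair therefore extends to the 2-methylphenyl group: none of the three methylphenyl variants separates from the others, and compounds 1, 2 and 3 cannot be ranked. No supporting data bear on why these values stay so close.

On these data alone, whether a different group on this phenyl ring, such as methoxy, chlorine or a carboxylic acid, would give a step beyond the scatter remains open. Also open, as far as these compounds go, is how a carbonyl in place of the thiocarbonyl would behave in the shared core.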